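A few compounds are considered here, and "the series" means these few. Any claim that something is new, unique, unknown or untested is made for them only; others in the source may bear on it.

Measured so far:
compound 1, `O=C(COc1ccc(C(=O)/C=C/c2ccccc2Br)cc1)N[C@H]1CCOC1=O` — 3540 nM
compound 2, `O=C(CNc1ccccc1Cl)N[C@H]1CCOC1=O` — a limit, > 64000 nM

Within the data shown here, in a functional assay on DU-145 cells (Homo sapiens) for antiproliferative activity, read by MTT assay, with a stated time of 72 h (a higher number here means a weaker inhibitor, a lower number a stronger inhibitor), compound 1 gives 3540 nM, the only number in the set. Compound 2 reaches only a limit in this assay, > 64000 nM. That boundary, (the limit of > 64000 nM in this assay, at which 1 of the 2 values shown sits), is where its value sits. Among the measured compounds shown here, compound 1 therefore stands alone as the single measured number, with nothing to rank it against.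

Compound 3 is `O=C(COc1ccc(C(=O)/C=C/c2ccccc2)cc1)N[C@H]1CCOC1=O`. It differs from compound 1 in one place: hydrogen in place of bromo on an aromatic carbon. No measured step of this kind exists among these compounds. The step of a 1.4-fold higher number from compound 1 to compound 3 (0.15 log units; within the scatter) is expected to be modest, at most a small loss near the scatter. Compound 3 is estimated at 5000 nM, within 1500 nM to 16000 nM.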

Compound 3, half-maximal inhibitory concentration: 48300 nM
For compound 3 the middle estimate is 9.7-fold (0.98 log units) below the measured one, and the stated range ends below it.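

In this assay, hydrogen in place of bromo on an aromatic carbon, ortho to a large group, gives a 14-fold higher number from compound 1 to compound 3 (1.13 log units; beyond the scatter) in a single change. The 2-bromophenyl end of the series is therefore not indifferent to what sits at this position, at least for this pair. Nothing shown here accounts for the size of the step.

From the compounds shown here alone, whether this step is specific to bromo remains open. A chloro, a methoxy or an amine on the same aromatic carbon would show how far it extends to other groups.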